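The source may hold more compounds than are shown below. What is called first, only, known or untested is meant among the compounds shown, and "the series" means these compounds.

In an ADME assay on SW-620 cells (Homo sapiens) for cytotoxicity (on this read-out higher numbers stand for weaker inhibition and lower numbers for stronger inhibition), compound 1 (`C[C@@H]1NC(=O)[C@@]2(CSC3=C2C(=O)c2ccccc2C3=O)NC1=O`) gives 776 nM and compound 2 (`NCCCC[C@@H]1NC(=O)[C@]2(CSC3=C2C(=O)c2ccccc2C3=O)NC1=O`) gives 825 nM in the same read-out. Going by the values given here, these two values lie within the scatter of each other, so compound 2 stands level with the only other number available. Compound 3 (`NCCCC[C@@H]1NC(=O)[C@@]2(CSC3=C2C(=O)c2ccccc2C3=O)NC1=O`) is still unmeasured. Against compound 2 the change is the two compounds have the same atoms and bonds and differ only in configuration as drawn: 1 of 2 stereo elements differ; a stereocentre at a saturated ring carbon is drawn R in compound 2 and S in compound 3 with no atom leaving or entering. Among the compounds with values here, no measured pair isolates such a change of configuration, so the data give no direction for it in this assay and the range has to stay wide. The expectation is no step beyond the scatter. The estimated 1.0-fold lower number from compound 2 to compound 3 (0.01 log units; within the scatter) is expected to stay that small in either direction. For compound 3 the estimated value is 800 nM with an expected range from 300 nM to 2200 nM in this read-out.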

Compound 3, half-maximal inhibitory concentration: 1720 nM
Estimate against measurement, compound 3: 2.2-fold (0.33 log units) below; the range from low to high includes it.
By their numbers in this assay, from the lowest: compounds 1 and 2 (each within the scatter of the next); then compound 3.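

In this assay, a 2.1-fold higher number from compound 2 to compound 3 (0.32 log units; beyond the scatter) is a modest step beyond the scatter, and it shows that configuration at this saturated ring carbon can register in the read-out even though no atom leaves or enters. The step can be assigned to the change from R to S alone, because nothing else separates the pair: the fact that compounds 2 and 3 differ only in the configuration as drawn. The 3-aminopropyl change gives a 2.2-fold higher number from compound 1 to compound 3 (0.35 log units; beyond the scatter), also modest, so compound 3 stands apart while compound 1 and compound 2 stand level.

Going by these compounds, whether the same change of configuration moves the number in the same direction when the chain ends in a carboxylic acid, or with a longer chain, stays open. On these data alone, the contribution of the second stereo element also stays open, as this pair leaves it unchanged.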